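This account rests on a few compounds, and the source may have more. Where it says the series, first, only, none or still open, it means among the compounds named here.

Compound 2 `c1ccc2c(-c3cn4ccnc4c(-c4ccc5ncn(C6CCCCC6)c5c4)n3)cccc2c1` carries a naphthalen-1-yl group on the shared core, and in a functional assay on HCT-15 cells (Homo sapiens) for inhibition, read by sulforhodamine B assay, with a stated time of 48 h, tested at 10 uM (on this read-out lower numbers stand for less inhibition and higher numbers for more inhibition at the one concentration tested (going by the name of the read-out)), compound 2 gives 4.46%. Among the three measured compounds it stands second highest. The nearest is compound 3 `c1cn2cc(-c3ccsc3)nc(-c3ccc4ncn(C5CCCCC5)c4c3)c2n1`, with a thiophen-3-yl group, which gives 1.37%. The two lie within the scatter of each other: a number 3.1 percentage points lower from compound 2 to compound 3 (within the scatter). The furthest is compound 1 `c1ccc(-c2cn3ccnc3c(-c3ccc4ncn(C5CCCCC5)c4c3)n2)cc1`, the phenyl parent, which gives 51.6%.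

Compound 4 `Fc1ccccc1-c1cn2ccnc2c(-c2ccc3ncn(C4CCCCC4)c3c2)n1` differs from compound 2 in one place: 2-fluorophenyl in place of naphthalen-1-yl on an aromatic carbon. Among the measured compounds shown here, the only measured step that bears on this change is a number 47.1 percentage points lower from compound 1 to compound 2 (beyond the scatter), a large fall when phenyl gave way to naphthalen-1-yl. For the measured compounds named here, the change to compound 4 goes the other way, back to a single six-membered ring of carbon only, now with a fluorine on it; no measured compound carries a fluorine, so its share is unknown. Compound 4 is therefore expected to rise by a number 35.5 percentage points higher from compound 2 to compound 4 (beyond the scatter) and to give 40%, with a range from 15% to 62%.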

Compound 4, a percentage reported as inhibition, at one concentration (the size of the read-out at that concentration, not a potency): 6.18%
Estimate against measurement, compound 4: 33.8 percentage points above; measured number below the stated range.
By their numbers in this assay, from the lowest: compounds 3, 2 and 4 (each within the scatter of the next); then compound 1.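

In this assay, a single fluoro on the phenyl group is enough to give a number 45.4 percentage points lower from compound 1 to compound 4 (beyond the scatter), so this position responds strongly even to the smallest of the changes shown. Going back to one six-membered aromatic ring of carbon only does not restore the read-out: the step is a number 1.7 percentage points higher from compound 2 to compound 4 (within the scatter), and a number 4.8 percentage points higher from compound 3 to compound 4 (within the scatter), so 2-fluorophenyl, naphthalen-1-yl and thiophen-3-yl cannot be told apart here, and of the four compounds only the unsubstituted phenyl of compound 1 stands clear of the rest. Nothing measured here explains this drop.

As far as these compounds go, it remains open whether the fall belongs to fluoro itself or would follow any group on the phenyl ring, such as a methyl, a methoxy or an amine. Whether any such group could keep the level of compound 1 is equally unsettled.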